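Benzothiazole substituent swap on a shared amide core

The compounds below may be only part of what the source reports. "The series", "measured", "known", "first", "only" and "open" are said of these compounds alone.

Measured so far:
- Compound 1 `O=C(Nc1nc2ccc(F)cc2s1)c1cc(-c2ccc(F)cc2)n2nc(-c3ccccc3)cc2n1` gives 14800 nM in a functional assay on A549 cells (Homo sapiens) for cytotoxicity, read by MTT assay, with a stated time of 48 h; on this read-out higher numbers stand for weaker inhibition and lower numbers for stronger inhibition.
- Compound 2 `COc1ccc(-c2cc(C(=O)Nc3nc4ccc(F)cc4s3)nc3cc(-c4ccccc4)nn23)cc1` gives 11700 nM in this assay.

Compound 2 sits at one end of the numbers shown and compound 1 at the other, but the only step between them, a 1.3-fold lower number from compound 1 to compound 2 (0.10 log units; within the scatter), lies within the scatter, so the two cannot be told apart. Compound 3 `COc1ccc(-c2cc(C(=O)Nc3nc4cc(C)c(C)cc4s3)nc3cc(-c4ccccc4)nn23)cc1` differs from compound 2 by 5,6-dimethyl-1,3-benzothiazol-2-yl in place of 6-fluoro-1,3-benzothiazol-2-yl on an amide-type nitrogen. Among the compounds with values here, no measured step touches this part of the molecule; the single known step changes a different ring and was itself small. Nothing in the data therefore points to a step beyond the scatter in this assay, in either direction. Compound 3 is expected to give about 10000 nM, with a range from 4000 nM to 30000 nM. The expected step from the measured neighbour amounts to a 1.2-fold lower number from compound 2 to compound 3 (0.07 log units; within the scatter).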

Compound 3, half-maximal inhibitory concentration: 13200 nM
The estimate for compound 3 lay 1.3-fold (0.12 log units) below the measured number; the range from low to high includes it.
By their numbers in this assay, from the lowest: compounds 2, 3 and 1 (each within the scatter of the next).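

Putting 5,6-dimethyl-1,3-benzothiazol-2-yl in place of 6-fluoro-1,3-benzothiazol-2-yl on the amide-type nitrogen gives a 1.1-fold higher number from compound 2 to compound 3 (0.05 log units; within the scatter) in this assay, so this change to the benzothiazole cannot be told apart from no change at all. Within the data shown here, this is the first look at this part of the molecule, and it shows that losing the fluorine and gaining two methyl groups leaves the number inside the scatter, as did the change on the other ring, a 1.3-fold lower number from compound 1 to compound 2 (0.10 log units; within the scatter). No separate measurement is available to explain why the number stays put here.

Going by these compounds, whether an amine or a carboxylic acid on the benzothiazole would move the number beyond the scatter remains open. Also open, on these data alone, is whether the same swap would behave alike with the fluoro group of compound 1 in place of the methoxy group.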